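Methyl in place of phenyl at the nitrogen ring

This account rests on a few compounds, and the source may have more. Where it says the series, first, only, none or still open, it means among the compounds named here.

Among the compounds with values here, compound 1 `O=C(O)CCc1ccc(C#Cc2ccnc(-c3ccccc3)c2)cc1` and compound 2 `O=C(O)CCc1ccc(C#Cc2cccnc2)cc1` are the two members measured so far, and their numbers sit together. In an in vitro functional assay on 1321-N1 cells for agonist activity at Free fatty acid receptor 1 (Homo sapiens), read by fluorescence, spectrophotometry and calcium flux (a higher number here means a larger maximal response, a lower number a smaller maximal response), compound 1 reaches 97%. In this assay compound 2 reaches 96%, and the gap between the two lies within the usual scatter, so neither stands apart from the other. Compound 3 `Cc1cc(C#Cc2ccc(CCC(=O)O)cc2)ccn1` is the next member to be measured and differs from compound 1 by methyl in place of phenyl on an aromatic carbon. Within the data shown here, no step between two measured compounds covers a change of this kind, so the expectation rests on the two values alone. Because compound 2, which carries no phenyl at all, gives 96%, removing the phenyl is not expected to cost efficacy, and the step of a number 2 percentage points lower from compound 1 to compound 3 (within the scatter) is expected to stay within the scatter. Compound 3 is therefore estimated to give 95% in this assay, with a range from 82% to 105%.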

Compound 3, largest response reached (reported as efficacy), in percent of the reference or control that the assay uses: 102%
Beside the measured number, compound 3's estimate is 7 percentage points below it; low and high end bracket the measured number.
By their numbers in this assay, from the lowest: compounds 2, 1 and 3 (each within the scatter of the next).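

In this assay, within the data shown here, the change from phenyl to methyl on the aromatic carbon next to the ring nitrogen gives a number 5 percentage points higher from compound 1 to compound 3 (within the scatter) and is the first step read at this position. A six-membered aromatic ring of carbon only leaves, a single methyl enters, and the maximal response of the two compounds cannot be told apart, so this position accepts either group in this read-out. No measurement shown bears on why the response holds across this change.

From the compounds shown here alone, whether an amine, a methoxy group or a longer alkyl chain on this same carbon would also hold the maximal response remains open. The compounds shown speak to maximal response alone, so the concentration needed to reach it also remains open for both phenyl and methyl.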